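The compounds below may be only part of what the source reports. "The series", "measured", "known", "first", "only" and "open" are said of these compounds alone.

Values in a functional assay on MDA-MB-231 cells (Homo sapiens) for antiproliferative activity, read by MTT assay, with a stated time of 72 h; on this read-out lower numbers stand for stronger inhibition and higher numbers for weaker inhibition:
Compound 1 `CC(C)(C)NC(=O)CCc1cccc2c1B(O)OC2`: > 100000 nM (a limit)
Compound 2 `O=C(CCc1cccc2c1B(O)OC2)NC1CCCCC1`: > 100000 nM (a limit)
Compound 3 `O=C(CCc1cccc2c1B(O)OC2)Nc1ccc(Br)cc1`: 5300 nM

Going by the values given here, compound 3 gives 5300 nM, the only true number among the three. The other two values are limits, so compound 3 can be placed only against those limits and not against another exact value.

Compound 4 `Cc1ccc(NC(=O)CCc2cccc3c2B(O)OC3)cc1` differs from compound 3 at one place: methyl in place of bromo on an aromatic carbon. This is methyl in place of bromo on an aromatic carbon, para to a large group, so 4-bromophenyl becomes 4-methylphenyl.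

Among the compounds with values here, no measured step makes this exact change. The nearest evidence comes from replacing the whole group on the amide-type nitrogen. Putting 4-bromophenyl in place of tert-butyl gives an at least 18-fold lower number from compound 1 to compound 3 (1.27 log units; beyond the scatter), and putting it in place of cyclohexyl gives an at least 18-fold lower number from compound 2 to compound 3 (1.27 log units; beyond the scatter). Both steps are large, but neither separates the phenyl from its bromo. Compound 4 keeps the phenyl, so a fall back to the limit seems unlikely, though it cannot be ruled out.

In this assay, the expected result is a 1.4-fold higher number from compound 3 to compound 4 (0.15 log units; within the scatter), with no change beyond the scatter and only a slight lean toward a higher number. For compound 4 the estimated value is 7500 nM, with an expected range from 2500 nM to 25000 nM.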

Compound 4, half-maximal inhibitory concentration: 1100 nM
For compound 4 the middle estimate is 6.8-fold (0.83 log units) above the measured one; measured number below the stated range.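

In this assay the change of bromo to methyl on an aromatic carbon, para to a large group, gives a 4.8-fold lower number from compound 3 to compound 4 (0.68 log units; beyond the scatter). Going by these compounds alone, until now the only changes on the amide-type nitrogen replaced the whole group, so this is the first sign that the small group on the phenyl also matters, and not only the presence of the phenyl itself. The wider comparisons read an at least 90-fold lower number from compound 2 to compound 4 (1.95 log units; beyond the scatter) and an at least 90-fold lower number from compound 1 to compound 4 (1.95 log units; beyond the scatter), but these sizes are only minimum values because the starting compound in each step sits at a limit: the limit of > 100000 nM in this assay, at which 2 of the 4 values shown sit.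

With only bromo and methyl at this place, two compounds cannot show a trend, and nothing here says which difference between the two groups matters or how a plain phenyl, a chloro, a methoxy or an amine would behave there. The compounds shown also leave open whether the gain from methyl would hold with a longer chain linking the amide carbonyl to the shared core.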